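This account rests on a few compounds, and the source may have more. Where it says the series, first, only, none or still open, it means among the compounds named here.

The measured compounds:
Compound 1, `[O-]/[N+](=C\c1cn(CCC(F)(F)C(F)(F)C(F)(F)C(F)(F)C(F)(F)C(F)(F)C(F)(F)C(F)(F)F)nn1)c1ccccc1`, gives > 100000 nM in a functional assay on MDA-MB-231 cells (Homo sapiens) for inhibition, read by MTT assay, with a stated time of 24 h; a higher number here means a weaker inhibitor, a lower number a stronger inhibitor; that value is a limit of the assay, not a number.
Compound 2, `[O-]/[N+](=C\c1cn(CCC(F)(F)C(F)(F)C(F)(F)C(F)(F)C(F)(F)C(F)(F)C(F)(F)C(F)(F)F)nn1)Cc1ccccc1`, gives 8400 nM in this assay.
Compound 3, `CC(C)(C)/[N+]([O-])=C/c1cn(CCC(F)(F)C(F)(F)C(F)(F)C(F)(F)C(F)(F)C(F)(F)F)nn1`, gives 9800 nM in this assay.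

Compound 3 and compound 2 give numbers that lie within the scatter of each other, so compound 3 stands level with the one other number shown and apart from the limit of compound 1. That limit is the limit of > 100000 nM in this assay, at which 1 of the 3 values shown sits. Going by the values given here, the only step among the measured compounds is an at least 11-fold lower number from compound 1 to compound 2 (1.07 log units; beyond the scatter), and it changes the group on the double-bonded nitrogen while leaving the perfluorinated chain untouched. Compound 4, `CC(C)(C)/[N+]([O-])=C/c1cn(CCC(F)(F)C(F)(F)C(F)(F)C(F)(F)C(F)(F)C(F)(F)C(F)(F)C(F)(F)F)nn1`, differs from compound 3 by 1,1,2,2,2-pentafluoroethyl in place of fluoro on a saturated chain carbon bound to two fluorine atoms and a saturated chain carbon. Among the compounds with values here, no measured step alters that chain, so the data give no direction for this change, and compound 2 and compound 3, which differ in both the nitrogen group and the chain, sit within the scatter of each other. In this assay compound 4 is therefore expected to give about 9000 nM, between 3000 nM and 30000 nM, a step of a 1.1-fold lower number from compound 3 to compound 4 (0.04 log units; within the scatter) that is expected to stay within the scatter.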

Compound 4, half-maximal inhibitory concentration: 29700 nM
Estimate against measurement, compound 4: 3.3-fold (0.52 log units) below, within the range that was stated.
By their numbers in this assay, from the lowest: compounds 2 and 3 (each within the scatter of the next); then compound 4. At a limit, above all of these: compound 1.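

Going by these compounds alone, the chain carbon that no earlier step had touched turns out to matter, since 1,1,2,2,2-pentafluoroethyl in place of fluoro there gives a weaker inhibitor (a 3.0-fold higher number from compound 3 to compound 4 (0.48 log units; beyond the scatter)). With the chain now held constant, the nitrogen group can also be compared directly, and tert-butyl in place of benzyl costs a similar amount (a 3.5-fold higher number from compound 2 to compound 4 (0.55 log units; beyond the scatter)). Against phenyl the step is only a bound (an at least 3.3-fold lower number from compound 1 to compound 4 (0.52 log units; beyond the scatter)), and the reading of compound 1 is a limit, not a number: the limit of > 100000 nM in this assay, at which 1 of the 4 values shown sits.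

As far as these compounds go, how the number would run with a benzyl group on the shorter chain stays open, so it cannot be said whether the chain and nitrogen steps simply add. Also open, from the compounds shown here alone, is how a cyclohexyl group on the nitrogen, or an unfluorinated alkyl chain in place of the fluorinated one, would behave in this assay.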